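Swapping Nitro for Amino on Two Related Cores

The source may hold more compounds than are shown below. What is called first, only, known or untested is meant among the compounds shown, and "the series" means these compounds.

Four compounds share most of their structure and differ in two places. Compound 1 `COc1ccc(-c2c(-c3cc(OC)c(OC)c(OC)c3)ssc2=O)cc1[N+](=O)[O-]` carries a nitro group; compound 2 `COc1ccc(-c2c(-c3cc(OC)c(OC)c(OC)c3)ssc2=O)cc1N` carries an amino group in its place, and amino in place of nitro on an aromatic carbon describes that difference. Compound 3 `COc1ccc(-c2c(-c3cc(OC)c(OC)c(OC)c3)ss/c2=N/O)cc1[N+](=O)[O-]` rests on a core that also differs from the core of compound 1, but the difference between the two cores is not broken down here. Compound 4 `COc1ccc(-c2c(-c3cc(OC)c(OC)c(OC)c3)ss/c2=N/O)cc1N` stands to compound 3 as compound 2 stands to compound 1: amino in place of nitro on an aromatic carbon describes the same change at the same place.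

In a functional assay on SGC-7901 cells (Homo sapiens) for antiproliferative activity, read by MTT assay, with a stated time of 72 h (on this read-out lower numbers stand for stronger inhibition and higher numbers for weaker inhibition), compound 1 gives > 100000 nM, which is a limit of the assay and not a number. Compound 2 gives > 100000 nM in this assay, again a limit. The step that the two limits leave unreadable from compound 1 to compound 2 therefore cannot be read, since both values sit at the limit of > 100000 nM in this assay, at which 2 of the 3 values shown sit. Going by the values given here, compound 3 gives 6560 nM in this assay, the only number among the three measured compounds.

What replacing nitro by amino does to potency is thus unknown from the measured pair. Compound 4 is expected to lie a step of a 2.3-fold higher number from compound 3 to compound 4 (0.36 log units; beyond the scatter) away, with wide uncertainty. That expectation rests on compound 3 at 6560 nM and on the unreadable step that the two limits leave unreadable from compound 1 to compound 2, which leaves open whether the amino compound keeps, loses or gains activity. Compound 4 is estimated at 15000 nM, between 3000 nM and 100000 nM.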

Compound 4, half-maximal inhibitory concentration: 2910 nM
For compound 4 the middle estimate is 5.2-fold (0.71 log units) above the measured one, outside the stated range (below it).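

In this assay putting amino in place of nitro on an aromatic carbon gives a 2.3-fold lower number from compound 3 to compound 4 (0.35 log units; beyond the scatter) and, since lower numbers stand for stronger inhibition here, the amino compound of this pair is modestly the stronger inhibitor. On the core of compound 1 the same change cannot be read, because compound 1 and compound 2 both give a limit of the assay and not a number: the limit of > 100000 nM in this assay, at which 2 of the 4 values shown sit. Going by these compounds alone, the series therefore offers only one readable pair, so it shows what the change does on one core and cannot show whether that effect carries over to the other: the data neither confirm nor contradict a shared trend, and a modest gain on one core is no basis for a general rule about swapping nitro for amino.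

On these data alone, it remains open how other groups at the same place, ortho to a methoxy group, would compare with nitro and amino on the core of compound 3, for example a hydroxyl, a methyl or an acetamide. The compounds shown also leave open whether a change at this place could bring the core of compound 1 to a readable value in this assay.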